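The compounds below may be only part of what the source reports. "The series", "measured", "known", "first", "only" and "open" are said of these compounds alone.

Working notes on the series. Compound 2 `c1c[nH]c(-c2ccccc2OCC2=NCCN2)c1` gives 99% in a functional assay with Alpha-1A adrenergic receptor (Homo sapiens) as the target, read by calcium flux; a lower number here means a smaller maximal response, a higher number a larger maximal response; its nearest neighbour, compound 1 `c1cnc(-c2ccccc2OCC2=NCCN2)nc1`, gives 90% in this assay, and the two numbers lie within the usual scatter of each other. Going by the values given here, the single measured step, a number 9 percentage points higher from compound 1 to compound 2 (within the scatter), bears on the next change, since it too exchanges one five-membered aromatic ring with one hetero atom for another. Compound 3 `c1ccc(-c2ccoc2)c(OCC2=NCCN2)c1` remains to be measured; the change is furan-3-yl in place of 1H-pyrrol-2-yl on an aromatic carbon. Because a number 9 percentage points higher from compound 1 to compound 2 (within the scatter) stayed within the scatter, no step beyond the scatter is expected, a number 7 percentage points lower from compound 2 to compound 3 (within the scatter). Compound 3 is therefore estimated at 92%, range 75% to 105%.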

Compound 3, largest response reached (reported as maximum), in percent of the reference or control that the assay uses: 104%
Compound 3: the middle estimate sits 12 percentage points below what was measured, within the range that was stated.
By their numbers in this assay, from the lowest: compounds 1, 2 and 3 (each within the scatter of the next, the first and the last beyond it).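

At this position on the aromatic carbon, the exchange of a ring bearing a hydrogen-bond donor for one bearing a hydrogen-bond acceptor does not separate the two compounds in this assay: a number 5 percentage points higher from compound 2 to compound 3 (within the scatter). Furan-3-yl in place of pyrimidin-2-yl gives the first step beyond the scatter, though a modest one: a number 14 percentage points higher from compound 1 to compound 3 (beyond the scatter). Nothing available explains either step.

Still open, on these data alone, is whether a non-aromatic group at this position, such as an amine, a carboxylic acid or a longer chain, would keep this maximal response.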